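The source may hold more compounds than are shown below. What is called first, only, known or untested is meant among the compounds shown, and "the series" means these compounds.

Compound 1 `CC(C)n1ncc2c(C(=O)NCc3cn(-c4ccccc4)nn3)cccc21` gives 26000 nM in a functional assay on PC-3 cells (Homo sapiens) for inhibition, read by MTT assay, with a stated time of 72 h; a lower number here means a stronger inhibitor, a higher number a weaker inhibitor.
Compound 2 `CC(C)n1ncc2c(C(=O)NCc3cn(-c4ccc([N+](=O)[O-])cc4)nn3)cccc21` reaches only a limit in this assay, reported as > 40000 nM.
Compound 3 `Cc1ccccc1-n1cc(CNC(=O)c2cccc3c2cnn3C(C)C)nn1` gives 19200 nM in this assay.

Of the two actual numbers, that of compound 3 is the lower one, yet the gap to compound 1, a 1.4-fold lower number from compound 1 to compound 3 (0.13 log units; within the scatter), sits within the ordinary scatter of repeated measurements, so the two cannot be told apart with confidence. The third value is a limit rather than a number.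

Compound 4 `CC(C)n1ncc2c(C(=O)NCc3cn(-c4ccccc4F)nn3)cccc21` differs from compound 3 by fluoro in place of methyl on an aromatic carbon. Two measured steps speak to this change. The methyl that compound 4 now gives up was itself what set compound 3 apart from compound 1, and that addition barely moved the number. Replacing the whole nitrophenyl with the methylphenyl gave an at least 2.0-fold lower number from compound 2 to compound 3 (0.31 log units; beyond the scatter). As far as these compounds go, compound 2 sits at the limit of > 40000 nM in this assay, at which 1 of the 3 values shown sits, so the true size of that step is unknown.

Since swapping a single small group on this carbon has so far shifted this assay only within the scatter, the expected step of a 1.0-fold higher number from compound 3 to compound 4 (0.02 log units; within the scatter) is small, with no clear direction. Compound 4 is therefore estimated at about 20000 nM, plausibly between 8000 nM and 45000 nM.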

Compound 4, half-maximal inhibitory concentration: > 40000 nM
Compound 4: only a limit was reported; the forecaster's own chance of this, stated with the estimate: 20%; middle value at least 2.0-fold (0.30 log units) from the limit.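

Fluoro in place of methyl on this carbon, ortho to a large group, gives an at least 2.0-fold higher number from compound 3 to compound 4 (0.31 log units; beyond the scatter) in this assay, so exchanging one small group here can move the number past the scatter, which methyl in place of hydrogen did not do between compound 1 and compound 3. Measured against the unsubstituted phenyl, the same fluoro gives an at least 1.5-fold higher number from compound 1 to compound 4 (0.18 log units; that floor lies within the scatter), a floor too small to show whether fluoro truly differs from hydrogen at this carbon. The value of compound 4 is only a limit, as is that of compound 2, so the true sizes of these steps remain unknown, and the step between those two compounds cannot be read because both rest on the same limit: the limit of > 40000 nM in this assay, at which 2 of the 4 values shown sit.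

The compounds shown leave open how far compound 4 actually lies from compound 3, and so whether the methyl of compound 3 offers any real gain over hydrogen. They also leave open how chloro, methoxy or an amine on this same carbon would compare with methyl and fluoro.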